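The compounds below may be only part of what the source reports. "The series", "measured", "known", "first", "only" and "open" are said of these compounds alone.

Measured compounds:
compound 1 `CC1(C)CC(=O)N(c2ccccc2C(=O)OCC2CCCN(CCCc3ccccc3)C2)C1=O`, 4900 nM
compound 2 `O=C(OCC1CCCN(CCCc2ccccc2)C1)c1ccccc1-c1cccc2ccccc12`, 11700 nM

In an in vitro functional assay on HEK ts201 cells for antagonist activity at Neuronal acetylcholine receptor; alpha4/beta2 (Homo sapiens), read by fluorescence and calcium flux (a lower number here means a stronger inhibitor, a higher number a weaker inhibitor), compound 2 gives the highest of the two numbers recorded; its nearest neighbour is compound 1, and the change a 2.4-fold higher number from compound 1 to compound 2 (0.38 log units; beyond the scatter) accompanied the replacement of 3,3-dimethyl-2,5-dioxopyrrolidin-1-yl by naphthalen-1-yl on an aromatic carbon.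

Compound 3 `O=C(OCC1CCCN(CCCc2ccccc2)C1)c1ccccc1N1C(=O)c2ccccc2C1=O` is not yet measured in this assay. It differs from compound 2 by a group of 11 heavy atoms (8 carbon, 1 nitrogen, 2 oxygen; one five-membered non-aromatic ring with 1 hetero atom, one six-membered aromatic ring of carbon only) in place of a group of 10 heavy atoms (10 carbon; 2 six-membered aromatic rings of carbon only), on an aromatic carbon. The entering group shares with the group of compound 1 a five-membered non-aromatic ring with one hetero atom and two double bonds outside aromatic rings, whereas naphthalen-1-yl carries only aromatic rings of carbon.

Going by the values given here, only one measured step bears on this change, namely a 2.4-fold higher number from compound 1 to compound 2 (0.38 log units; beyond the scatter), which ran in the direction of a weaker inhibitor when the five-membered ring was removed. Reversing that kind of change is therefore expected to give a lower number, of about the size seen there; compound 3 is estimated to lie near compound 1 rather than compound 2, with the step of a 2.1-fold lower number from compound 2 to compound 3 (0.33 log units; beyond the scatter) expected. The estimate for compound 3 in this assay is 5500 nM, within the range 2000 nM to 15000 nM.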

Compound 3, half-maximal inhibitory concentration: 5010 nM
Compound 3: the middle estimate sits 1.1-fold (0.04 log units) above what was measured; measured number inside the range.
By their numbers in this assay, from the lowest: compounds 1 and 3 (each within the scatter of the next); then compound 2.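

In this assay, a second group with a five-membered non-aromatic ring with one hetero atom and two double bonds outside aromatic rings now stands on this aromatic carbon, and the step away from naphthalen-1-yl (a 2.3-fold lower number from compound 2 to compound 3 (0.37 log units; beyond the scatter)) is close in size to the earlier step in the opposite direction (a 2.4-fold higher number from compound 1 to compound 2 (0.38 log units; beyond the scatter)), so the gap to naphthalen-1-yl no longer rests on the group of compound 1 alone. The two groups that carry this ring cannot be told apart in this assay (a 1.0-fold higher number from compound 1 to compound 3 (0.01 log units; within the scatter)), so the added six-membered aromatic ring of carbon in compound 3 and the 3,3-dimethyl groups of compound 1 give numbers within the scatter of each other. No measurement at hand speaks to the reason for the gap between these groups and naphthalen-1-yl.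

Going by these compounds alone, with only three groups at this position, it remains open whether the ring or its two double bonds outside aromatic rings go with the lower numbers; an open-chain acetamide, an amine or a carboxylic acid on the same aromatic carbon would begin to separate these. As far as these compounds go, all three compounds share the remainder of the core, so it is also open whether the gap would persist with a shorter chain on the ring nitrogen.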